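A few compounds are considered here, and "the series" means these few. Any claim that something is new, unique, unknown or untested is made for them only; others in the source may bear on it.

Measured compounds:
- compound 1, `COc1ccc(-c2cc(/C=C/C(=O)c3ccc(N)cc3)[nH]n2)cc1`, gives 58100 nM in a functional assay on 786-0 cells (Homo sapiens) for inhibition, read by sulforhodamine B assay, with a stated time of 48 h; on this read-out higher numbers stand for lower toxicity in this test and lower numbers for higher toxicity in this test
- compound 2, `COc1ccc(-c2cc(/C=C/C(=O)c3ccc(N)cc3)[nH]n2)cc1OC`, gives 10800 nM in this assay
- compound 3, `COc1cc(C(=O)/C=C/c2cc(-c3cc(OC)c(OC)c(OC)c3)n[nH]2)cc(OC)c1OC`, gives 6760 nM in this assay

Compound 2 and compound 1 differ in one place: hydrogen in place of methoxy on an aromatic carbon. That change made a step of a 5.4-fold higher number from compound 2 to compound 1 (0.73 log units; beyond the scatter). Compound 3 and compound 2 differ by more than one place; the difference between the two cores is not broken down here. Compound 3 and compound 2 lie within the scatter of each other, while compound 3 and compound 1 lie beyond it.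

Compound 4, `COc1ccc(-c2cc(/C=C/C(=O)c3cc(OC)c(OC)c(OC)c3)[nH]n2)cc1OC`, has not yet been measured in this assay. It differs from compound 3 by hydrogen in place of methoxy on an aromatic carbon. Among the measured compounds shown here, this is the same kind of change as the one from compound 2 to compound 1, though the surroundings are not identical: in compound 3 the changed place is also meta to a methoxy group (2 heavy atoms), which is not the case in compound 2.

For the measured compounds named here, only one measured example of this kind of change exists here, so the expectation rests on a single step. Going from compound 3 to compound 4, the number is expected to rise by roughly the same amount, because of a 5.4-fold higher number from compound 2 to compound 1 (0.73 log units; beyond the scatter). For compound 4 the estimated step is a 4.7-fold higher number from compound 3 to compound 4 (0.68 log units; beyond the scatter). Compound 4 is therefore expected to give about 32000 nM in this assay, with a likely range from 10000 nM to 90000 nM.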

Compound 4, concentration lethal to 50% of the cells: 5600 nM
Compound 4: middle estimate off by 5.7-fold (0.76 log units), on the high side, outside the stated range (below it).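

In this assay, replacing a methoxy group with hydrogen on the core of compound 3 gave a step that does not stand out from the usual scatter (a 1.2-fold lower number from compound 3 to compound 4 (0.08 log units; within the scatter)), so on this core the swap left no readable mark. Set beside the earlier example, the same swap did not carry over from one core to the other: the same change on two cores in this assay, a 5.4-fold higher number (0.73 log units; beyond the scatter) from compound 2 to compound 1 and a 1.2-fold lower number (0.08 log units; within the scatter) from compound 3 to compound 4, 6.5-fold (0.81 log units) apart, beyond the scatter of two such steps. Among the compounds shown here, this shows that a step measured on one core of this series cannot simply be transferred to another, but it rests on only two pairs of compounds; compound 2 and compound 3 differ in more than one place, so it does not show which part of the cores separates the two outcomes, or which of the two steps is the more typical.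

The compounds shown leave open whether a hydroxyl group, a fluorine atom or a longer chain such as ethoxy, placed where the methoxy group stood, would behave like hydrogen on either core. They also leave open how the same swap behaves on further cores, and whether such cores would follow the first step, the second, or neither.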